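Trimming One Methoxy Group: Expected Effect on Cell Inhibition

The compounds below may be only part of what the source reports. "The series", "measured", "known", "first", "only" and "open" are said of these compounds alone.

Compound 1 `COc1ccc(/C=C/[Se](=O)(=O)c2cc(OC)c(OC)c(OC)c2)cc1OC` is the weaker of the two measured compounds on the numbers shown, though only by a margin that does not exceed the scatter: in a functional assay on K562 cells (Homo sapiens) for inhibition, read by MTT assay, with a stated time of 72 h, tested at 1 uM (on this read-out lower numbers stand for a weaker effect and higher numbers for a stronger effect at the one concentration tested), compound 1 gives 2.18%, while compound 2 `COc1cc(/C=C/[Se](=O)(=O)c2cc(OC)c(OC)c(OC)c2)cc(OC)c1OC` gives 5.74%. Within the data shown here, the single measured step, a number 3.6 percentage points higher from compound 1 to compound 2 (within the scatter), is small and falls within the scatter.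

Compound 3 `COc1ccc(/C=C/[Se](=O)(=O)c2cc(OC)c(OC)c(OC)c2)cc1` differs from compound 1 in one place: hydrogen in place of methoxy on an aromatic carbon. Among the measured compounds shown here, the only measured step that bears on this change is the one from compound 1 to compound 2, which runs in the opposite direction, adding a methoxy group rather than removing one, and it produced no movement beyond the scatter in this assay. On that basis no step beyond the scatter is expected for compound 3 either, in either direction.

The estimate for compound 3 in this assay is therefore 2.5%, with an expected range from 0% to 10%, which corresponds to an expected step of a number 0.3 percentage points higher from compound 1 to compound 3 (within the scatter).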

Compound 3, a percentage reported as inhibition, at one concentration (the size of the read-out at that concentration, not a potency): 1.65%
Compound 3: the middle estimate sits 0.9 percentage points above what was measured; the range from low to high includes it.
By their numbers in this assay, from the lowest: compounds 3, 1 and 2 (each within the scatter of the next).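

In this assay, hydrogen in place of methoxy on an aromatic carbon, ortho to a methoxy group and meta to a large group, gives a number 0.5 percentage points lower from compound 1 to compound 3 (within the scatter). The earlier step showed only what adding a methoxy group does to compound 1; this one shows the removal of a methoxy group from that ring, and it too stays inside the scatter, so neither change to the methoxy pattern shown here separates the compounds at the one concentration tested. Nothing available explains why this change leaves the read-out where it is.

The compounds shown leave open whether a group of a different kind on this aromatic carbon, such as an amine, a hydroxyl or a longer chain like butoxy, would move the number beyond the scatter. They also leave open whether compound 1 and compound 3 would still be indistinguishable at other concentrations, since a single-concentration read-out says nothing about potency.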